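Thiophen-3-yl in place of phenyl on the chloro compound

The source may report more compounds than this note shows. Statements on the series, on what has been measured and on what is new or still open speak of the compounds shown alone.

In a functional assay on A549 cells (Homo sapiens), read by sulforhodamine B assay, with a stated time of 5 days (a lower number here means a stronger inhibitor of growth, a higher number a weaker inhibitor of growth), compound 3 (`OC[C@H]1O[C@@H](n2cc(Cl)c3c(-c4ccccc4)ncnc32)[C@H](O)[C@@H]1O`) gives 2500 nM. Compound 2 (`OC[C@H]1O[C@@H](n2cc(F)c3c(-c4ccoc4)ncnc32)[C@H](O)[C@@H]1O`) gives 60 nM, so compound 3 holds the higher of the two exact numbers. Compound 1 (`OC[C@H]1O[C@@H](n2cc(F)c3c(-c4ccccc4)ncnc32)[C@H](O)[C@@H]1O`) reads > 10000 nM, which is a limit of the assay and not a number.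

Compound 4 (`OC[C@H]1O[C@@H](n2cc(Cl)c3c(-c4ccsc4)ncnc32)[C@H](O)[C@@H]1O`) has thiophen-3-yl in place of phenyl on an aromatic carbon. The closest measured change is furan-3-yl in place of phenyl, seen as an at least 160-fold lower number from compound 1 to compound 2 (2.22 log units; beyond the scatter). That large step was measured with fluoro rather than chloro on the core, and it starts from the limit. Chloro in place of fluoro, seen as an at least 4.0-fold lower number from compound 1 to compound 3 (0.60 log units; beyond the scatter), starts from the same limit and is at least modest. Among the measured compounds shown here, no thiophen-3-yl compound has been measured yet, so the transfer is uncertain.

A large step to a lower number is expected, and the estimated change in this assay is a 25-fold lower number from compound 3 to compound 4 (1.40 log units; beyond the scatter). For compound 4 the estimated value is 100 nM, with an expected range of 20 nM to 600 nM.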

Compound 4, concentration for 50% growth inhibition: 380 nM
Compound 4: the middle estimate sits 3.8-fold (0.58 log units) below what was measured; low and high end bracket the measured number.
By their numbers in this assay, from the lowest: compound 2; then compound 4; then compound 3. At a limit, above all of these: compound 1.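

Among the compounds shown here, with chloro on the core in this assay, thiophen-3-yl in place of phenyl gives a 6.6-fold lower number from compound 3 to compound 4 (0.82 log units; beyond the scatter), the only step at this position with an exact number at both ends. A lower number on replacing phenyl with a five-membered aromatic ring therefore appears on the chloro core as well as in the fluoro pair, although the entering ring differs between the two pairs. The fluoro pair starts from compound 1, whose value is a limit and not a number: the limit of > 10000 nM in this assay, at which 1 of the 4 values shown sits.

Going by these compounds, how furan-3-yl and thiophen-3-yl compare on a single core remains open, as does the effect of fluoro against chloro once phenyl is replaced. Also open, on these data alone, is how a pyridin-3-yl ring, or an aminomethyl or carboxylic acid group on the entering ring, would read in this assay.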